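A few compounds are considered here, and "the series" means these few. Any claim that something is new, unique, unknown or untested is made for them only; others in the source may bear on it.

Compound 2 `O=c1cc(Cn2cc(CCCCO)nn2)c2ccc(O)cc2o1` is the starting point of this step. In a functional assay on A549 cells (Homo sapiens) for inhibition, read by MTT assay, with a stated time of 72 h (a lower number here means a stronger inhibitor, a higher number a weaker inhibitor), compound 2 gives > 100000 nM, which is a limit of the assay and not a number. Compound 1 `O=c1cc(Cn2cc(CCCCl)nn2)c2ccc(O)cc2o1` carries chloro where compound 2 carries hydroxymethyl, and in this assay compound 1 gives 30100 nM. Among the measured compounds shown here, the one measured step, an at least 3.3-fold higher number from compound 1 to compound 2 (0.52 log units; beyond the scatter), thus runs toward the weaker side, with the limit of > 100000 nM in this assay, at which 1 of the 2 values shown sits, marking how far it could be followed. Compound 3 `CCCCCCCCc1cn(Cc2cc(=O)oc3cc(O)ccc23)nn1` is the next compound; the change is butyl in place of hydroxy on a saturated chain carbon, four bonds along the chain from an aromatic carbon, so the hydroxy gained between compound 1 and compound 2 is gone again and the chain is longer. For the measured compounds named here, only that measured step bears on this change, and it points the opposite way, so a reversal of at least that size is expected in this assay, toward a lower number. Compound 3 is estimated at 30000 nM, within 8000 nM to 100000 nM. The expected step is an at least 3.3-fold lower number from compound 2 to compound 3 (0.52 log units; beyond the scatter).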

Compound 3, half-maximal inhibitory concentration: 46000 nM
Beside the measured number, compound 3's estimate is 1.5-fold (0.19 log units) below it; the measured number falls inside the stated range.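

In this assay, butyl in place of hydroxy on a saturated chain carbon, four bonds along the chain from an aromatic carbon, gives an at least 2.1-fold lower number from compound 2 to compound 3 (0.33 log units; beyond the scatter) and so reverses the loss seen with the hydroxy-bearing chain. Pentyl in place of chloro gives a 1.5-fold higher number from compound 1 to compound 3 (0.18 log units; within the scatter) and so shows that the chain end need not carry chloro to stay level with compound 1 in this assay. As far as these compounds go, the value of compound 2 is a limit of the assay and not a number, and because of it the true size of the step from that compound stays open: the limit of > 100000 nM in this assay, at which 1 of the 3 values shown sits.

From the compounds shown here alone, whether an amine or a carboxylic acid at the chain end would read like hydroxy or like chloro stays open. Also open, going by these compounds, is whether a longer chain would take the number past that of compound 1 at 30100 nM in this assay on the shared core.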